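Bis-benzimidazole series: naphthalen-2-yl variant of compound 1

The source may hold more compounds than are shown below. What is called first, only, known or untested is meant among the compounds shown, and "the series" means these compounds.

Compound 1 `Cc1cccc(-c2nc3cc(-c4nc5cc(C#N)ccc5[nH]4)ccc3[nH]2)c1` gives 860 nM in a functional assay on RPMI 8402 cells (Homo sapiens) for cytotoxicity; a lower number here means a stronger inhibitor, a higher number a weaker inhibitor. Among the three measured compounds it carries the highest number, yet no gap separates it from the others: compound 2 `Cc1ccc(-c2nc3cc(-c4nc5cc(C#N)ccc5[nH]4)ccc3[nH]2)cc1` gives 570 nM in this assay, a step of a 1.5-fold lower number from compound 1 to compound 2 (0.18 log units; within the scatter), so the three stand together.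

Compound 4 `N#Cc1ccc2[nH]c(-c3ccc4[nH]c(-c5ccc6ccccc6c5)nc4c3)nc2c1` is not yet measured. The change from compound 1 is naphthalen-2-yl in place of 3-methylphenyl on an aromatic carbon. The step that bears most directly on it is the one in which the other naphthyl isomer entered the same position: compound 3 `N#Cc1ccc2[nH]c(-c3ccc4[nH]c(-c5cccc6ccccc56)nc4c3)nc2c1` gives 650 nM in this assay, and the step is a 1.3-fold lower number from compound 1 to compound 3 (0.12 log units; within the scatter). The pair of naphthyl and methylphenyl groups also shows a 1.1-fold higher number from compound 2 to compound 3 (0.06 log units; within the scatter). For the measured compounds named here, every replacement at this position so far has stayed inside the scatter, so no step beyond it is expected here either.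

Compound 4 is therefore expected to give 620 nM in this assay, with a range of 250 nM to 1500 nM. The expected step is a 1.4-fold lower number from compound 1 to compound 4 (0.14 log units; within the scatter).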

Compound 4, half-maximal inhibitory concentration: 130 nM
Compound 4: the middle estimate sits 4.8-fold (0.68 log units) above what was measured; the measured number lies below the stated range.
By their numbers in this assay, from the lowest: compound 4; then compounds 2, 3 and 1 (each within the scatter of the next).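

The position is not as indifferent as the three earlier compounds suggested: in (this assay), changing only the attachment point of the naphthyl group, with the same heavy atoms, separates the two isomers (a 5.0-fold lower number from compound 3 to compound 4 (0.70 log units; beyond the scatter)). Ring count alone does not track the number, as compound 3 also carries two six-membered aromatic rings yet stays within the scatter of compound 1 and compound 2. The naphthalen-2-yl group also stands apart from both methylphenyl groups (a 6.6-fold lower number from compound 1 to compound 4 (0.82 log units; beyond the scatter)) and (a 4.4-fold lower number from compound 2 to compound 4 (0.64 log units; beyond the scatter)), leaving compound 4 alone beyond the scatter of the others.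

Nothing available explains why the two naphthyl isomers differ. As far as these compounds go, whether the lower number is particular to naphthalen-2-yl or carries over to a quinolin-3-yl group, a biphenyl-4-yl group or a phenyl ring bearing an amine remains open.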